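Chloro for trifluoromethyl on the terminal aryl urea

The compounds below may be only part of what the source reports. "The series", "measured", "known", "first", "only" and "open" are said of these compounds alone.

Working notes on the semicarbazide series. In a functional assay on HeLa cells (Homo sapiens) for inhibition, read by MTT assay, with a stated time of 72 h (a lower number here means a stronger inhibitor, a higher number a weaker inhibitor), compound 3 `COc1cc(NC(C)CCCNC(=O)NNC(=O)Nc2cccc(C(F)(F)F)c2)c2ncccc2c1` gives 4900 nM, the lowest number among the values in hand. Compound 2 `COc1cc(NC(C)CCCNC(=O)Nc2ccc(F)cc2)c2ncccc2c1` gives 20000 nM in this assay. Compound 1 `COc1cc(NC(C)CCCNC(=O)NNC(=O)Nc2cccc(F)c2)c2ncccc2c1` gives only a limit of the assay in this assay, > 250000 nM, and not a number (the limit of > 250000 nM in this assay, at which 1 of the 3 values shown sits).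

Compound 4 `COc1cc(NC(C)CCCNC(=O)NNC(=O)Nc2cccc(Cl)c2)c2ncccc2c1` differs from compound 3 as follows: chloro in place of trifluoromethyl on an aromatic carbon. The measured step that bears on this change is an at least 51-fold lower number from compound 1 to compound 3 (1.70 log units; beyond the scatter), where fluoro on the same aromatic carbon gave a limit and trifluoromethyl a number; the step was large. The step of an at least 12-fold lower number from compound 1 to compound 2 (1.09 log units; beyond the scatter) changes a different part of the molecule and speaks only indirectly. Chloro is a third substituent on this aromatic carbon, and no measured pair shows chloro against either fluoro or trifluoromethyl, so the direction rests on compound 3 being the reference point with 4900 nM. A moderate rise in the number is expected for compound 4, a 1.8-fold higher number from compound 3 to compound 4 (0.26 log units; within the scatter), possibly still within the scatter. The estimate for compound 4 in this assay is 9000 nM, in the range 3000 nM to 30000 nM.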

Compound 4, half-maximal inhibitory concentration: 44000 nM
Estimate against measurement, compound 4: 4.9-fold (0.69 log units) below; measured number above the stated range.
By their numbers in this assay, from the lowest: compound 3; then compound 2; then compound 4. At a limit, above all of these: compound 1.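

In this assay, the substituent on this aromatic carbon alone moves the number beyond the scatter, and chloro does not stand in for trifluoromethyl: a 9.0-fold higher number from compound 3 to compound 4 (0.95 log units; beyond the scatter). Chloro still gives a measured number where fluoro does not, an at least 5.6-fold lower number from compound 1 to compound 4 (0.75 log units; beyond the scatter), which puts the three groups in the order trifluoromethyl, chloro, fluoro, with the last place resting on compound 1 at a limit and not a number: the limit of > 250000 nM in this assay, at which 1 of the 4 values shown sits. Against the 4-fluorophenyl urea, the chloro semicarbazide lies on the higher side, a 2.2-fold higher number from compound 2 to compound 4 (0.34 log units; beyond the scatter), so among the semicarbazides with a number only the trifluoromethyl one lies on the lower side of compound 2.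

Open, from the compounds shown here alone, is whether a nitrile, a methoxy or a methyl on this carbon would fall below trifluoromethyl or near chloro. Also open, going by these compounds, is whether the same order holds on the urea of compound 2.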